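Aminophenyl for Fluorobenzyl: Expected Cytotoxicity of Compound 4

This account rests on a few compounds, and the source may have more. Where it says the series, first, only, none or still open, it means among the compounds named here.

Compound 1 `Cc1ccccc1-c1nn(-c2ccc(F)cc2F)cc1CNCCN1CCCCC1` gives > 20000 nM in an ADME assay on Huh-7 cells (Homo sapiens) for cytotoxicity; a higher number here means that more compound is tolerated, a lower number that less compound is tolerated; this is a limit of the assay, not a number.
Compound 2 `Cc1ccccc1-c1nn(Cc2ccc(F)cc2)cc1CNCCN1CCN(C)CC1` gives > 20000 nM in this assay; this too is a limit.
Compound 3 `CN1CCN(CCCNCc2cn(-c3ccc(C(F)(F)F)cc3)nc2-c2ccc(C(F)(F)F)cc2)CC1` gives 2000 nM in this assay.

Compound 2 therefore stands at the ceiling of what was measured: only a limit is known for it, and (the limit of > 20000 nM in this assay, at which 2 of the 3 values shown sit). Going by the values given here, compound 3 is the only one of the three with an actual number, and it is the one carrying two trifluoromethyl groups rather than a 2-methylphenyl group.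

Compound 4 `Cc1ccccc1-c1nn(-c2ccc(N)cc2)cc1CNCCN1CCN(C)CC1` differs from compound 2 in a single place: 4-aminophenyl in place of 4-fluorobenzyl on an aromatic nitrogen. Among the compounds with values here, no step between two measured compounds is available to show how a change at this position moves the read-out, so the expectation rests on the three values alone. In this assay the step is expected to be none beyond the scatter, with compound 4 again likely to reach the limit. The step that the limit leaves unreadable from compound 2 to compound 4 is expected to be small. Compound 4 is expected to give 25000 nM, within a range from 8000 nM to 60000 nM.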

Compound 4, half-maximal cytotoxic concentration: > 20000 nM
Compound 4 ended at the assay's limit (the forecaster's own chance of this, stated with the estimate: 70%); the middle value is on the limit's open side.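

Compound 2 and compound 4 both end at a limit of this assay, not at a number, so no step can be read between them: the limit of > 20000 nM in this assay, at which 3 of the 4 values shown sit.

Whether 4-aminophenyl in place of 4-fluorobenzyl on an aromatic nitrogen moves the read-out in this assay at all remains open in the compounds shown.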